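The source may hold more compounds than are shown below. What is called first, only, known or untested is meant among the compounds shown, and "the series" means these compounds.

In an ADME assay on MT4 cells (Homo sapiens) for cytotoxicity, read by MTT assay, with a stated time of 5 days (on this read-out lower numbers stand for higher toxicity in this test and higher numbers for lower toxicity in this test), compound 3 `O=C1N(Cc2ccccc2Br)c2cccn2S(=O)(=O)N1Cc1ccccc1` gives 226000 nM. For compound 1 `O=C1N(Cc2ccccc2Cl)c2cccn2S(=O)(=O)N1Cc1ccccc1` this assay returns only a limit, > 291000 nM. The two differ by chloro in place of bromo on an aromatic carbon, and that change brings an at least 1.2-fold higher number from compound 3 to compound 1 (0.10 log units; that floor lies within the scatter), a floor set by the limit of the limit of > 291000 nM in this assay, at which 1 of the 3 values shown sits.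

For compound 2 `O=C1N(Cc2ccc(Cl)cc2Cl)c2cccn2S(=O)(=O)N1Cc1cccc(Br)c1` this assay again returns only a limit, > 243000 nM. How the core of compound 2 differs from the core of compound 3 is not broken down here.

Compound 4 `O=C1N(Cc2ccc(Cl)cc2Cl)c2cccn2S(=O)(=O)N1Cc1cccc(Cl)c1` has not yet been tested in this assay. Against compound 2 it shows (chloro in place of bromo on an aromatic carbon). For the measured compounds named here, this is the same kind of change as the one from compound 3 to compound 1, though the surroundings differ: in compound 1 the chloro sits ortho to a large group, in compound 4 it sits meta to a large group.

The expectation for compound 4 rests on that earlier step and on the limit seen for compound 2 at the limit of > 243000 nM in this assay, at which 1 of the 3 values shown sits: the step from compound 3 to compound 1 was an at least 1.2-fold higher number from compound 3 to compound 1 (0.10 log units; that floor lies within the scatter), so the step from compound 2 to compound 4 is expected to be a step that the limit leaves unreadable from compound 2 to compound 4, most likely ending again at a limit rather than a number. Compound 4 is therefore estimated to give 300000 nM in this assay, somewhere between 150000 nM and 600000 nM.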

Compound 4, half-maximal cytotoxic concentration: > 251000 nM
Compound 4 ended at the assay's limit; the forecaster's own chance of this, stated with the estimate: 80%; the middle value lies beyond the limit too.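

In this assay, compound 2 and compound 4 both return only limits rather than numbers, and the step between them, chloro in place of bromo on the 3-benzyl group, cannot be read. The compounds shown leave open the true half-maximal cytotoxic concentrations of compound 1, compound 2 and compound 4, and whether chloro in place of bromo shifts this read-out in either pair.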